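The compounds below may be only part of what the source reports. "The series", "measured", "known", "first", "only" and "open" are said of these compounds alone.

Measured so far:
compound 1 `O=C(N/N=C/c1cccc(Cl)c1)c1cccnc1Nc1cccc(C(F)(F)F)c1`: 55.2%
compound 2 `O=C(N/N=C/c1ccc(O)c(O)c1)c1cccnc1Nc1cccc(C(F)(F)F)c1`: 38.2%

Both numbers come from a functional assay on the whole organism (strain Wistar) for inhibition, with Rattus norvegicus as the target, read by paw edema, with a stated time of 3 h, at a dose of 10 mg/kg by the intraperitoneal route (on this read-out lower numbers stand for less inhibition and higher numbers for more inhibition at the one dose given (going by the name of the read-out)), in which compound 1 gives 55.2% and compound 2 gives 38.2%. Among the compounds with values here, compound 2 holds the lower of the two numbers; its only neighbour is compound 1, and the single measured step, a number 17 percentage points lower from compound 1 to compound 2 (beyond the scatter), runs downward. Compound 3 `COc1ccc(/C=N/NC(=O)c2cccnc2Nc2cccc(C(F)(F)F)c2)c(OC)c1` differs from compound 2 in one place: 2,4-dimethoxyphenyl in place of 3,4-dihydroxyphenyl on a carbon with a double bond to nitrogen. Within the data shown here, no measured step shows this exact exchange. Among the measured compounds shown here, the one measured step bears on it only loosely, because a number 17 percentage points lower from compound 1 to compound 2 (beyond the scatter) shows that 3,4-dihydroxyphenyl gives a lower number than 3-chlorophenyl on the same carbon. For the measured compounds named here, compound 3 takes away 3,4-dihydroxyphenyl and brings in 2,4-dimethoxyphenyl, so a modest rise back toward compound 1 is expected, though the incoming ring is not the one of compound 1 and the step could also stay within the scatter. Compound 3 is expected to give 48%, with a range from 30% to 65%. The expected step of a number 9.8 percentage points higher from compound 2 to compound 3 (within the scatter) is therefore upward and modest.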

Compound 3, a percentage reported as inhibition, in the whole organism at one dose (the size of the read-out at that dose, not a potency): 24.1%
The estimate for compound 3 lay 23.9 percentage points above the measured number, and the stated range ends above it.
By their numbers in this assay, from the lowest: compound 3; then compound 2; then compound 1.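

In this assay, this position on a carbon with a double bond to nitrogen proves more sensitive than the earlier pair could show: 2,4-dimethoxyphenyl in place of 3,4-dihydroxyphenyl gives a number 14.1 percentage points lower from compound 2 to compound 3 (beyond the scatter), so the fall seen with compound 2 was not the floor for this series, and replacing a ring with two oxygen-bearing groups by another such ring does not restore the number. Set against the chlorinated ring, the same 2,4-dimethoxyphenyl gives a number 31.1 percentage points lower from compound 1 to compound 3 (beyond the scatter), the largest step so far, and among these three compounds the 3-chlorophenyl ring stands highest, with both oxygen-bearing rings beneath it. Nothing available explains why the number falls at this position.

This exchange alters both the kind of group, hydroxyl to methoxy, and the numbers in the ring's name, so the two changes cannot be told apart here; 3,4-dimethoxyphenyl, which changes only the first, would separate them. Also open, as far as these compounds go, is how a ring carrying an amine or a carboxylic acid would behave at this position, and whether these differences at one dose would hold at other doses.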